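This account rests on a few compounds, and the source may have more. Where it says the series, first, only, none or still open, it means among the compounds named here.

Cytotoxicity notes on the series. Compound 1 `Cc1c(O)nc(SCc2ccccc2)nc1Cc1c(Cl)cccc1Cl` in a functional assay on MT4 cells (Homo sapiens) for cytotoxicity, read by MTT assay (on this read-out lower numbers stand for higher toxicity in this test and higher numbers for lower toxicity in this test), gives > 64000 nM, which is a limit of the assay rather than a number (the limit of > 64000 nM in this assay, at which 1 of the 2 values shown sits). Compound 2 `CCCCOc1ccc(CSc2nc(O)c(C)c(Cc3c(Cl)cccc3Cl)n2)cc1` in this assay gives 3100 nM, the only number shown here. Going by the values given here, the one measured step is an at least 20-fold lower number from compound 1 to compound 2 (1.31 log units; beyond the scatter). Compound 3 `Cc1c(O)nc(SCc2ccc(Br)cc2)nc1Cc1c(Cl)cccc1Cl` differs from compound 2 by bromo in place of butoxy on an aromatic carbon. That measured step bears on this change: the butoxy that brought the large drop leaves and only bromo enters, and a step back toward the limit is expected, a 6.5-fold higher number from compound 2 to compound 3 (0.81 log units; beyond the scatter). Compound 3 is thus estimated at 20000 nM, between 5000 nM and 64000 nM.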

Compound 3, half-maximal cytotoxic concentration: 13000 nM
For compound 3 the middle estimate is 1.5-fold (0.19 log units) above the measured one; low and high end bracket the measured number.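

In this assay, the aromatic carbon para to a large group lowers the number with bromo as well, which gives an at least 4.9-fold lower number from compound 1 to compound 3 (0.69 log units; beyond the scatter), so the drop is not confined to butoxy. Butoxy still goes further, with a 4.2-fold higher number from compound 2 to compound 3 (0.62 log units; beyond the scatter), so the size of the drop depends on the group that enters. Compound 1 stands at a limit, so its step to compound 3 is a bound only: the limit of > 64000 nM in this assay, at which 1 of the 3 values shown sits.

As far as these compounds go, whether the number follows the heavy-atom count of the entering group stays open with only bromo and butoxy at this carbon. A longer chain such as hexyloxy, an amine or a carboxylic acid there would bear on this.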